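Adding a Second Fluorine to the Anilino Ring

The source may report more compounds than this note shows. Statements on the series, on what has been measured and on what is new or still open speak of the compounds shown alone.

Measured compounds in a functional assay for agonist activity at Glucose-dependent insulinotropic receptor (Mus musculus), read by cAMP accumulation; on this read-out lower numbers stand for smaller maximal responses and higher numbers for larger maximal responses:
- compound 1, `CC1(OC(=O)N2C[C@H]3COC[C@@H](C2)[C@@H]3Oc2ncnc(Nc3ccc(C#N)cc3Cl)c2F)CC1`: 99%
- compound 2, `CC1(OC(=O)N2C[C@H]3COC[C@@H](C2)[C@@H]3Oc2ncnc(Nc3ccccc3F)c2F)CC1`: 76%
- compound 3, `CC1(OC(=O)N2CC3COCC(C2)C3Oc2ncnc(Nc3ccc(F)cc3F)c2F)CC1`: 73%

All three share one core and differ only in the aryl group attached to the nitrogen on the aromatic ring. Compound 2 stands second highest of the three numbers in this assay. Its nearest neighbour is compound 3, whose value lies within the scatter of repeated measurements, so the two cannot be told apart. Compound 1 sits clearly above it: the step of a number 23 percentage points lower from compound 1 to compound 2 (beyond the scatter) is beyond the scatter and counts as modest.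

Compound 4, `CC1(OC(=O)N2C[C@H]3COC[C@@H](C2)[C@@H]3Oc2ncnc(Nc3c(F)cccc3F)c2F)CC1`, is not yet measured. It differs from compound 2 by fluoro in place of hydrogen on an aromatic carbon, placed on an aromatic carbon of a six-membered aromatic ring of carbon only, ortho to a large group and meta to a fluoro group.

Going by the values given here, no measured step adds a single fluorine to this ring, so the only direct guide is the pair compound 2 and compound 3, which also differ by one fluorine on the same ring and give values within the scatter. Among the compounds with values here, the only step that does exceed the scatter, from compound 1 to compound 2, involves a much larger exchange of groups. A small step, if any, is therefore expected: a number 1 percentage points lower from compound 2 to compound 4 (within the scatter). Compound 4 is estimated at 75%, within 60% to 90%.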

Compound 4, largest response reached (reported as percent of maximum), in percent of the reference or control that the assay uses: 108%
Compound 4: the middle estimate sits 33 percentage points below what was measured, and the stated range ends below it.
By their numbers in this assay, from the lowest: compounds 3 and 2 (each within the scatter of the next); then compounds 1 and 4 (each within the scatter of the next).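

Going from 2-fluorophenyl to 2,6-difluorophenyl swaps a single hydrogen for a fluoro group, yet in this assay it gives a number 32 percentage points higher from compound 2 to compound 4 (beyond the scatter), so this spot on the ring, ortho to a large group, can strongly affect the maximal response. Replacing the larger 2-chloro-4-cyanophenyl group with 2,6-difluorophenyl gives a number 9 percentage points higher from compound 1 to compound 4 (within the scatter), which means the two compounds cannot be told apart, and the chloro and nitrile groups of compound 1 are not required for a response of this size. Nothing available here explains why one added fluoro group changes the response so much.

Going by these compounds, it remains open whether fluorine itself matters at this spot or whether another small group, such as a methyl or a methoxy group, would give a similar rise. These numbers also describe only the largest response reached, so they leave open how much of each compound is needed to produce it.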